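This account rests on a few compounds, and the source may have more. Where it says the series, first, only, none or still open, it means among the compounds named here.

Measured compounds:
Compound 1, `CCOC(=O)C1=C(Nc2ccccc2)S/C(=C\c2ccc(O)c(O)c2)C1=O`: in a functional assay on JAR cells (Homo sapiens) for inhibition, read by MTT assay, with a stated time of 72 h (a lower number here means a stronger inhibitor, a higher number a weaker inhibitor), compound 1 gives 6100 nM.
Compound 2, `CCOC(=O)C1=C(Nc2ccccc2)S/C(=C\c2ccc([N+](=O)[O-])c(O)c2)C1=O`: in this assay compound 2 gives 12700 nM.

Compound 1 stands lowest of the two numbers in this assay. Going by the values given here, the only other number is a modest distance away: a 2.1-fold higher number from compound 1 to compound 2 (0.32 log units; beyond the scatter). That step exchanged one hydroxy for a nitro group on the aromatic ring and cost a little potency, beyond the scatter but not by much.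

Compound 3, `CCOC(=O)C1=C(Nc2ccccc2)S/C(=C\c2cccc(C(=O)O)c2)C1=O`, has not yet been measured in this assay. It differs from compound 1 in one place: 3-carboxyphenyl in place of 3,4-dihydroxyphenyl on a double-bonded chain carbon bound to a double-bonded ring carbon. Among the compounds with values here, only the step from compound 1 to compound 2 bears on this change, and only loosely, since there a single hydroxy was replaced while the other stayed, whereas in compound 3 both hydroxy groups leave and a carboxylic acid enters, a larger alteration than any measured here. Because a 2.1-fold higher number from compound 1 to compound 2 (0.32 log units; beyond the scatter) already raised the number when one hydroxy was lost, a rise of similar or somewhat larger size is expected for compound 3. Compound 3 is therefore estimated to give 13000 nM in this assay, with a range from 4500 nM to 40000 nM. That estimate corresponds to a 2.1-fold higher number from compound 1 to compound 3 (0.33 log units; beyond the scatter).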

Compound 3, half-maximal inhibitory concentration: 11700 nM
Compound 3: the middle estimate sits 1.1-fold (0.05 log units) above what was measured, within the range that was stated.
By their numbers in this assay, from the lowest: compounds 1, 3 and 2 (each within the scatter of the next, the first and the last beyond it).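

In this assay, the move to 3-carboxyphenyl in place of 3,4-dihydroxyphenyl gives a 1.9-fold higher number from compound 1 to compound 3 (0.28 log units; within the scatter), so this swap on the double-bonded chain carbon bound to a double-bonded ring carbon leaves two numbers that cannot be told apart. Compound 1 and compound 2 both kept a hydroxy on this aromatic ring, whereas compound 3 carries none and has a carboxylic acid instead, which shows that a number of this size does not depend on the 3,4-dihydroxyphenyl group being present on the shared core. No measurement is available that could account for this result.

Going by these compounds alone, the single swap replaces both hydroxy groups and brings in the carboxylic acid together, so the shares of the loss and the gain cannot be separated, and a lone hydroxy or a plain phenyl at this place would be needed to tell them apart. On these data alone, whether a methyl ester, an amide or an amine on the same ring would stay within the scatter of compound 1 also remains open.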